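Swapping a Cyanophenyl for a Dimethylphenyl: Permeability Outlook

The source may hold more compounds than are shown below. What is called first, only, known or untested is meant among the compounds shown, and "the series" means these compounds.

Two compounds have been measured in an ADME assay for permeability, using PAMPA, with a stated time of 30 min, at pH 7.4 (on this read-out lower numbers stand for lower permeability and higher numbers for higher permeability), so far:

Compound 1, `COc1ccc(F)cc1CNCCCNc1ccnc2cc(Cc3ccc(C#N)cc3)ccc12`, gives 23 10^-6 cm/s.
Compound 2, `COc1cccc(CNCCCNc2ccnc3cc(Cc4ccc(C#N)cc4)ccc23)c1O`, gives 23 10^-6 cm/s.

Compound 1 therefore stands level with compound 2: the step of no change at the digits printed from compound 1 to compound 2 (within the scatter) lies within the scatter of the method, and the two values cannot be told apart.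

Compound 3 is `COc1ccc(F)cc1CNCCCNc1ccnc2cc(Cc3cc(C)cc(C)c3)ccc12` and has not yet been measured in this assay. It differs from compound 1 as follows: 3,5-dimethylphenyl in place of 4-cyanophenyl on a saturated chain carbon bound to an aromatic carbon

Among the measured compounds shown here, none of the measured steps touches this part of the molecule. For the measured compounds named here, the only step seen, no change at the digits printed from compound 1 to compound 2 (within the scatter), replaced a group on the other saturated chain carbon and left the read-out unchanged. So there is no measured precedent for the present change; the one step available shows only that this core tolerated a change elsewhere without moving the number.

Given that, the step of a 1.1-fold higher number from compound 1 to compound 3 (0.04 log units; within the scatter) is expected to be small, with no clear direction beyond the scatter. The estimate for compound 3 in this assay is 25 10^-6 cm/s, with a range from 12 10^-6 cm/s to 50 10^-6 cm/s.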

Compound 3, apparent permeability: 23 10^-6 cm/s
Compound 3: middle estimate off by 1.1-fold (0.04 log units), on the high side, within the range that was stated.
By their numbers in this assay, from the lowest: compounds 1, 2 and 3 (each within the scatter of the next).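

In this assay, among the compounds shown here, putting 3,5-dimethylphenyl in place of 4-cyanophenyl on a saturated chain carbon bound to an aromatic carbon gives no change at the digits printed from compound 1 to compound 3 (within the scatter) and so provides the first measured step at this part of the molecule, which the earlier comparison left untouched. The two groups have the same count of 8 heavy atoms and each has an aromatic ring of carbon only, but they are not close relatives: the nitrile leaves, the methyl groups of 3,5-dimethylphenyl enter, and the two compounds still cannot be told apart on this read-out. No measurement at hand accounts for this, so it stands as an observation without an explanation.

Since the nitrile and the methyl groups were exchanged in one step, the compounds shown cannot say what each would do alone, for example in an unsubstituted phenyl or a 4-methylphenyl. On these data alone, it also remains open whether the read-out would stay level with a carboxylic acid or a primary amine on this ring, or whether the same exchange would give a similar result on the core of compound 2.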